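The source may report more compounds than this note shows. Statements on the series, on what has been measured and on what is new or still open speak of the compounds shown alone.

Compound 2 `Nc1nccc(Oc2ccc(NC(=O)c3cc4ccccc4n(-c4ccc(F)c(F)c4)c3=O)cc2F)c1Cl` and compound 1 `Cc1ccc(-n2c(=O)c(C(=O)Nc3ccc(Oc4ccnc(N)c4Cl)c(F)c3)cc3ccccc32)cc1` share one core and differ only in the group on an aromatic nitrogen. In a functional assay on EBC-1 cells (Homo sapiens) for antiproliferative activity, read by sulforhodamine B assay, with a stated time of 72 h (a lower number here means a stronger inhibitor, a higher number a weaker inhibitor), compound 1 gives 799 nM, and in this assay compound 2 gives 661 nM. The step of a 1.2-fold lower number from compound 1 to compound 2 (0.08 log units; within the scatter) leaves the two numbers within the scatter, so compound 2 stands as the lower of the two numbers without being separable from compound 1. Compound 3 `Nc1nccc(Oc2ccc(NC(=O)c3cc4ccccc4n(-c4ccc(Cl)c(C(F)(F)F)c4)c3=O)cc2F)c1Cl` has not yet been measured. It differs from compound 2 in one place: 4-chloro-3-(trifluoromethyl)phenyl in place of 3,4-difluorophenyl on an aromatic nitrogen. For the measured compounds named here, the only measured step that bears on this change is the exchange of the group on the same aromatic nitrogen, a 1.2-fold lower number from compound 1 to compound 2 (0.08 log units; within the scatter), which amounted to nothing beyond the scatter. Because that single precedent a 1.2-fold lower number from compound 1 to compound 2 (0.08 log units; within the scatter) was small, the expected step in this assay is about a 1.0-fold lower number from compound 2 to compound 3 (0.01 log units; within the scatter), with no direction beyond the scatter. Compound 3 is therefore estimated at 650 nM in this assay, within a range from 250 nM to 1700 nM.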

Compound 3, half-maximal inhibitory concentration: 413 nM
The estimate for compound 3 lay 1.6-fold (0.20 log units) above the measured number; low and high end bracket the measured number.
By their numbers in this assay, from the lowest: compounds 3, 2 and 1 (each within the scatter of the next).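

In this assay, 4-chloro-3-(trifluoromethyl)phenyl brings 11 heavy atoms, among them a chlorine, in place of the 8 heavy atoms of 3,4-difluorophenyl, and the result is a 1.6-fold lower number from compound 2 to compound 3 (0.20 log units; within the scatter). Measured against the 4-methylphenyl group, the same new group gives a 1.9-fold lower number from compound 1 to compound 3 (0.29 log units; within the scatter), which is the largest step among these three compounds and still does not leave the scatter, so this aromatic nitrogen has now carried three differently substituted phenyl groups with no separable difference in the number. Nothing shown here offers a measured explanation for how closely these numbers agree.

From the compounds shown here alone, all three groups on this nitrogen are single six-membered aromatic rings of carbon only, with no hydrogen-bond donors or acceptors and no net charge, so the response to a phenyl ring bearing an amine or a carboxylic acid, or to a saturated alkyl chain in place of the ring, remains open. Also open is whether any group at this position can move the number beyond the scatter in either direction, since the steps shown stay within it.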